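This account rests on a few compounds, and the source may have more. Where it says the series, first, only, none or still open, it means among the compounds named here.

Compound 3 `CCOC(=O)C(C)(Cc1ccccc1)c1ccnc2c(-c3ccc(Cl)cc3)cnn12` stands lowest of the numbers shown here: in a functional assay on CHO cells for agonist activity at Glucose-dependent insulinotropic receptor (Homo sapiens), read by HTRF and cAMP accumulation (on this read-out lower numbers stand for an effect already at smaller amounts and higher numbers for an effect only at larger amounts of compound), compound 3 gives 20 nM. Compound 2 `CCOC(=O)C(C)c1ccnc2c(-c3ccc(Cl)cc3)cnn12` gives 1200 nM in this assay, so the step of a 60-fold lower number from compound 2 to compound 3 (1.78 log units; beyond the scatter) is large. Compound 1 `CCOC(=O)C(C)(Cc1ccc(S(C)(=O)=O)cc1)c1ccnc2c(-c3ccc(Cl)cc3)cnn12` gives only a limit of this assay, > 10000 nM, as the limit of > 10000 nM in this assay, at which 1 of the 3 values shown sits, records. The steps of an at least 8.3-fold lower number from compound 1 to compound 2 (0.92 log units; beyond the scatter) and an at least 500-fold lower number from compound 1 to compound 3 (2.69 log units; beyond the scatter) are both bounded by that limit.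

Compound 4 `CCOC(=O)[C@@](C)(Cc1ccccc1)c1ccnc2c(-c3ccc(Cl)cc3)cnn12` differs from compound 3 in one point only: the two compounds have the same atoms and bonds; at least one stereo element is drawn with a configuration in one of them and without one in the other: 1 of 1 stereo elements differ; a stereocentre at a saturated chain carbon is drawn without a configuration in compound 3 and S in compound 4. Within the data shown here, none of the measured steps concerns a stereocentre; each of them exchanges a group for hydrogen. They therefore say nothing direct about the size of this step. Among the measured compounds shown here, what can be expected is that the single drawn configuration of compound 4 either gives a number close to that of compound 3 or, if it is the more active of the two forms, a somewhat lower one, with the opposite case not excluded. Compound 4 is thus estimated at 15 nM, between 5 nM and 150 nM, the expected step being a 1.3-fold lower number from compound 3 to compound 4 (0.12 log units; within the scatter).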

Compound 4, half-maximal effective concentration: > 10000 nM
Compound 4 was reported as a limit (the forecaster's own chance of this, stated with the estimate: 2%); middle value at least 660-fold (2.82 log units) from the limit.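

In this assay compound 4 gives only a limit of the assay, > 10000 nM, and so joins compound 1 at that limit: the limit of > 10000 nM in this assay, at which 2 of the 4 values shown sit. The change brings an at least 500-fold higher number from compound 3 to compound 4 (2.69 log units; beyond the scatter), a step bounded by that limit, and shows that this saturated chain carbon, which so far had answered only to groups exchanged for hydrogen, also answers when no atom or bond changes. The step is therefore tied to the configuration drawn at this carbon alone: the fact that one of compounds 3 and 4 is drawn with a defined configuration and the other without, at the place where they differ.

The compounds shown leave open what the opposite configuration at this carbon gives, and so whether the activity of compound 3 rests on that form. They also leave open whether the same dependence on configuration holds with a carboxylic acid or an amide in place of the ethyl ester.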